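Replacing the morpholin-4-yl group of compound 2

The compounds below may be only part of what the source reports. "The series", "measured", "known", "first", "only" and "open" are said of these compounds alone.

Of the compounds shown here, two sharing one core have been measured so far. In a functional assay on U-937 cells (Homo sapiens) for antiproliferative activity, read by MTT assay, with a stated time of 24 h (on this read-out higher numbers stand for weaker inhibition and lower numbers for stronger inhibition), compound 1 (`CCCCc1oc2ccccc2c1C(=O)c1ccc(OCC(=O)N2CCCC2)cc1`) gives 32500 nM, and compound 2 (`CCCCc1oc2ccccc2c1C(=O)c1ccc(OCC(=O)N2CCOCC2)cc1`) gives 45400 nM. Going by the values given here, the one measured step, a 1.4-fold higher number from compound 1 to compound 2 (0.15 log units; within the scatter), exchanges pyrrolidin-1-yl for morpholin-4-yl on a carbonyl carbon. Among the compounds with values here, compound 2 therefore cannot be told apart from the only other measured compound.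

Compound 3 (`CCCCc1oc2ccccc2c1C(=O)c1ccc(OCC(=O)N[C@@H](C)c2ccccc2)cc1`) differs from compound 2 as follows: (1-phenylethyl)amino in place of morpholin-4-yl on a carbonyl carbon. In words, (1-phenylethyl)amino stands in place of morpholin-4-yl on a carbonyl carbon, and the entering group holds a six-membered aromatic ring of carbon only. The measured step bears on this change only in part. Within the data shown here, it concerns the same place, but no measured compound carries a group of this kind. Among the measured compounds shown here, with a 1.4-fold higher number from compound 1 to compound 2 (0.15 log units; within the scatter) as the sole guide, no step beyond the scatter is firmly expected in this assay, and the direction remains uncertain. The estimated step is a 1.5-fold lower number from compound 2 to compound 3 (0.18 log units; within the scatter). For compound 3 the expected value is 30000 nM, with an estimated range from 10000 nM to 80000 nM.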

Compound 3, half-maximal inhibitory concentration: 33800 nM
Beside the measured number, compound 3's estimate is 1.1-fold (0.05 log units) below it; low and high end bracket the measured number.
By their numbers in this assay, from the lowest: compounds 1, 3 and 2 (each within the scatter of the next).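

In this assay, the place on the carbonyl carbon now holds a group of a different kind, (1-phenylethyl)amino, which brings a six-membered aromatic ring of carbon only, a hydrogen-bond donor and a defined stereocentre, yet the number stays within the scatter: a 1.3-fold lower number from compound 2 to compound 3 (0.13 log units; within the scatter), and a 1.0-fold higher number from compound 1 to compound 3 (0.02 log units; within the scatter). The three compounds thus cannot be told apart in this read-out, so pyrrolidin-1-yl, morpholin-4-yl and (1-phenylethyl)amino, for all their differences in ring type and in size, serve alike at this place on the evidence of these three compounds alone. Nothing available gives any reason for this even result.

The compounds shown leave open whether a benzylamino group, a piperazin-1-yl group or the opposite configuration of the (1-phenylethyl)amino group would shift the number beyond the scatter at this place. They also leave open whether a free carboxylic acid in place of the amide, or a chain other than butyl on the shared core, would move it out of the narrow band that these three compounds occupy.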